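A longer alkenyl amide on a weaker core

The compounds below may be only part of what the source reports. "The series", "measured", "known", "first", "only" and "open" are said of these compounds alone.

Measured so far in a functional assay on A549 cells (Homo sapiens) for antiproliferative activity, read by MTT assay, with a stated time of 72 h; on this read-out higher numbers stand for weaker inhibition and lower numbers for stronger inhibition:
compound 1 `C=CC(=O)Nc1cc(Nc2nccc(-c3cn(C)c4ccc(F)cc34)n2)c(OC)cc1N(C)CCN(C)C` gives 329 nM
compound 2 `CC/C=C\C(=O)Nc1cc(Nc2nccc(-c3cn(C)c4ccc(F)cc34)n2)c(OC)cc1N(C)CCN(C)C` gives 3600 nM
compound 3 `C=CC(=O)Nc1cc(Nc2ncc(C#N)c(-c3cn(C)c4ccc(F)cc34)n2)c(OC)cc1N(C)CCN(C)C` gives 9700 nM

Compound 1 is the starting point. Replacing its alkenyl amide, (but-1-en-1-yl in place of vinyl on a carbonyl carbon), produced an 11-fold higher number from compound 1 to compound 2 (1.04 log units; beyond the scatter). Changing the core instead, (cyano in place of hydrogen on an aromatic carbon), produced a 29-fold higher number from compound 1 to compound 3 (1.47 log units; beyond the scatter), and compound 3 shows the highest number of the three.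

Compound 4 `CC/C=C\C(=O)Nc1cc(Nc2ncc(C#N)c(-c3cn(C)c4ccc(F)cc34)n2)c(OC)cc1N(C)CCN(C)C` is not yet measured. It carries the same change that separates compound 1 from compound 2, now made on the core of compound 3: but-1-en-1-yl in place of vinyl on a carbonyl carbon. Within the data shown here, the surroundings of the change are the same in both pairs, so this is the same change seen once already, and the earlier step it made is the only guide. Compound 4 is expected to lie a 6.2-fold higher number from compound 3 to compound 4 (0.79 log units; beyond the scatter) from compound 3, resting on the step of an 11-fold higher number from compound 1 to compound 2 (1.04 log units; beyond the scatter) and on the high value of compound 3 in this assay, which leaves room for the number to run past what the assay resolves. The estimate for compound 4 is 60000 nM, with a range from 20000 nM to 200000 nM.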

Compound 4, half-maximal inhibitory concentration: 4730 nM
For compound 4 the middle estimate is 13-fold (1.10 log units) above the measured one; measured number below the stated range.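

In this assay, but-1-en-1-yl in place of vinyl on the carbonyl carbon gave a 2.1-fold lower number from compound 3 to compound 4 (0.31 log units; beyond the scatter), so on the cyano-bearing core the change did not repeat the loss seen on the core of compound 1, and its direction reversed: the same change on two cores in this assay, an 11-fold higher number (1.04 log units; beyond the scatter) from compound 1 to compound 2 and a 2.1-fold lower number (0.31 log units; beyond the scatter) from compound 3 to compound 4, 22-fold (1.35 log units) apart, beyond the scatter of two such steps
Read the other way, cyano in place of hydrogen on the aromatic carbon gave only a 1.3-fold higher number from compound 2 to compound 4 (0.12 log units; within the scatter), a difference that cannot be told from the scatter, although the same change was costly on the vinyl amide: the same change on two cores in this assay, a 29-fold higher number (1.47 log units; beyond the scatter) from compound 1 to compound 3 and a 1.3-fold higher number (0.12 log units; within the scatter) from compound 2 to compound 4, 22-fold (1.35 log units) apart, beyond the scatter of two such steps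
The two changes therefore do not add up in this series, so a step measured on one of these cores cannot be carried to the other, but four compounds show only that this happens here and do not show why.

As far as these compounds go, whether a chloro group on that aromatic carbon would also remove the penalty of the longer amide remains open. So does whether a propenyl chain or a saturated butanoyl amide would follow but-1-en-1-yl on either core.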